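A benzyl group in place of the halogenated aryl

The source may report more compounds than this note shows. Statements on the series, on what has been measured and on what is new or still open speak of the compounds shown alone.

Measured compounds:
compound 1, `CCC(CC)N(CCN(C)C(=O)CCC(=O)O)Cc1cccc(C(=O)Nc2sc3c(c2C(=O)c2cnn(-c4ccc(Cl)c(C(F)(F)F)c4)c2)CCC(C)(C)C3)c1`, 38 nM
compound 2, `CCC(CC)N(CCN(C)C(=O)CCC(=O)O)Cc1cccc(C(=O)Nc2sc3c(c2C(=O)c2cnn(-c4ccc(Cl)cc4)c2)CCOC3)c1`, 437 nM
compound 3, `CCC(CC)N(CCN(C)C(=O)CCC(=O)O)Cc1cccc(C(=O)Nc2sc3c(c2C(=O)c2cnn(-c4ccc(Cl)cc4)c2)CCN(C2CC2)C3)c1`, 80 nM

In an assay on isolated protein for inhibition of sodium-dependent phosphate transport protein 2B (Homo sapiens) (on this read-out higher numbers stand for weaker inhibition and lower numbers for stronger inhibition), compound 1 gives the lowest of the three numbers. Compound 3 comes nearest, with a higher number at a gap beyond the usual scatter, and compound 2 lies furthest away, also with a higher number beyond the usual scatter. Compound 2 and compound 3 differ from compound 1 both in the aryl ring and in the shared core, so no single change can be read from their values.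

Compound 4, `CCC(CC)N(CCN(C)C(=O)CCC(=O)O)Cc1cccc(C(=O)Nc2sc3c(c2C(=O)c2cnn(Cc4ccccc4)c2)CCC(C)(C)C3)c1`, has not yet been measured. It differs from compound 1 in one place: benzyl in place of 4-chloro-3-(trifluoromethyl)phenyl on an aromatic nitrogen. Among the measured compounds shown here, no measured pair isolates this change, so its size is uncertain. The step from compound 1 to compound 4 is expected to weaken inhibition, by a 7.9-fold higher number from compound 1 to compound 4 (0.90 log units; beyond the scatter), beyond the scatter. For compound 4 the estimate in this assay is 300 nM, with a range from 80 nM to 1200 nM.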

Compound 4, half-maximal inhibitory concentration: 179 nM
Beside the measured number, compound 4's estimate is 1.7-fold (0.22 log units) above it; measured number inside the range.
By their numbers in this assay, from the lowest: compound 1; then compound 3; then compound 4; then compound 2.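

Among the compounds shown here, replacing 4-chloro-3-(trifluoromethyl)phenyl with benzyl on the aromatic nitrogen gives, in this assay, a 4.7-fold higher number from compound 1 to compound 4 (0.67 log units; beyond the scatter), the first change at this position that can be read on its own. The step is modest, and inhibition is weakened without being lost: compound 4, which carries no halogen on its aromatic ring, still gives 179 nM. Nothing measured here accounts for the size of this step.

The change alters both the substituents on the ring and its link to the nitrogen, so the compounds shown do not separate these contributions; an unsubstituted phenyl or a 4-chlorobenzyl group on the same nitrogen would bear on this. As far as these compounds go, whether the step would be the same on the cores of compound 2 and compound 3 also remains open.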